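Thiazolyl acetamides: methoxy on the anilino phenyl ring

The source may report more compounds than this note shows. Statements on the series, on what has been measured and on what is new or still open speak of the compounds shown alone.

Measured so far:
compound 1, `Cc1nc(SCC(=O)Nc2nc(-c3ccc(Cl)cc3)cs2)n(Nc2ccccc2)c1C`: 1840 nM
compound 2, `Cc1ccc(Nn2c(SCC(=O)Nc3nc(-c4ccccc4)cs3)nc(C)c2C)cc1`: 2820 nM

The two measured compounds were tested in a functional assay on HCT-116 cells (Homo sapiens) for antiproliferative activity, read by sulforhodamine B assay, with a stated time of 48 h; a lower number here means a stronger inhibitor of growth, a higher number a weaker inhibitor of growth. Compound 1 gives 1840 nM, the lower of the two numbers. Compound 2 gives 2820 nM, which lies within the scatter of compound 1, so the two cannot be ordered; compound 2 also differs from compound 1 in more than one place, so no single step can be read from the pair.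

Compound 3, `COc1ccc(Nn2c(SCC(=O)Nc3nc(-c4ccc(Cl)cc4)cs3)nc(C)c2C)cc1`, differs from compound 1 in one place: methoxy in place of hydrogen on an aromatic carbon. Nothing in the measured pair isolates a change at that position. Compound 2, carrying a different small group on that same phenyl ring alongside a second change elsewhere, sits within the scatter of compound 1, which gives no sign that substitution there moves the number far.

Compound 3 is therefore expected to fall close to compound 1, with the step of a 1.1-fold higher number from compound 1 to compound 3 (0.04 log units; within the scatter) estimated to stay within the scatter. For compound 3 the estimate in this assay is 2000 nM, with a range from 800 nM to 5000 nM.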

Compound 3, concentration for 50% growth inhibition: 2120 nM
The estimate for compound 3 lay 1.1-fold (0.03 log units) below the measured number; low and high end bracket the measured number.
By their numbers in this assay, from the lowest: compounds 1, 3 and 2 (each within the scatter of the next).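

For the compounds shown here, the phenyl to 4-methoxyphenyl change gives, in this assay, a 1.2-fold higher number from compound 1 to compound 3 (0.06 log units; within the scatter), and this is the first reading that isolates this position, since compound 2 carries a second change elsewhere. On the core of compound 1, methoxy para to a large group therefore leaves the number indistinguishable from that with hydrogen, so this position tolerates a group of 2 heavy atoms, with 1 hydrogen-bond acceptor and no hydrogen-bond donor, without a readable change in growth inhibition. No measurement available here bears on the reason for this result.

Still open, going by these compounds, is whether this tolerance extends to groups that differ more from methoxy at the same place, such as a dimethylamino group, a carboxylic acid or a longer chain such as butoxy. Also open, on these data alone, is whether methoxy gives the same reading at other places on this phenyl ring, or when the rest of the core of compound 3 is changed.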